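Opening of the methoxy analogue: compound 3 to compound 4

This account rests on a few compounds, and the source may have more. Where it says the series, first, only, none or still open, it means among the compounds named here.

Compound 3 `CC/C=C/COC1(c2ccc(Cl)cc2)SC=C(C)n2c1noc2=O` gives 55000 nM in a functional assay on A2780 cells (Homo sapiens) for antiproliferative activity, read by MTT assay, with a stated time of 3 days; on this read-out higher numbers stand for weaker inhibition and lower numbers for stronger inhibition. Its geometric partner compound 2 `CC/C=C\COC1(c2ccc(Cl)cc2)SC=C(C)n2c1noc2=O` gives 55000 nM, so the step of no change at the digits printed from compound 2 to compound 3 (within the scatter) is flat; nothing in the double-bond drawing the fact that one of compounds 2 and 3 is drawn with a defined configuration and the other without, at the place where they differ moves the number. Compound 1 `COC1(c2ccc(Br)cc2)SC=C(C)n2c1noc2=O` carries the bromo aryl and a methoxy group and gives 148000 nM, the highest of the three numbers; compounds 2 and 3 stand together at the lowest. Compound 4 `COC1(c2ccc(Cl)cc2)SC=C(C)n2c1noc2=O` is the methoxy counterpart of compound 3: hydrogen in place of but-1-en-1-yl on a saturated chain carbon bound to an oxygen on a saturated carbon. For the measured compounds named here, no measured step follows this change alone; compound 1 and compound 3 differ both in the halogen and in the ether chain, so their values only suggest that the short ether sits at the weaker end. Going by the values given here, the single measured step, from compound 2 to compound 3, is flat and does not bear on the chain shortening. The expectation for compound 4 is therefore a weaker value in this assay, a step of a 2.2-fold higher number from compound 3 to compound 4 (0.34 log units; beyond the scatter) toward the number of compound 1, estimated at 120000 nM with a range from 50000 nM to 300000 nM.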

Compound 4, half-maximal inhibitory concentration: 166000 nM
For compound 4 the middle estimate is 1.4-fold (0.14 log units) below the measured one; measured number inside the range.
By their numbers in this assay, from the lowest: compounds 2 and 3 (each within the scatter of the next); then compounds 1 and 4 (each within the scatter of the next).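

In this assay, for the compounds shown here, cutting the ether from (pent-2-en-1-yl)oxy to methoxy gives a 3.0-fold higher number from compound 3 to compound 4 (0.48 log units; beyond the scatter) and likewise a 3.0-fold higher number from compound 2 to compound 4 (0.48 log units; beyond the scatter) with the other double-bond geometry, so this is the first direct reading that the longer chain at this position goes with the lower number, for both geometries. With methoxy held fixed, chloro in place of bromo gives a 1.1-fold higher number from compound 1 to compound 4 (0.05 log units; within the scatter) and so does not separate the two halogens in this pair. Nothing measured in this set bears on why the chain step occurs.

As far as these compounds go, whether the step follows chain length or the double bond remains open, as the series shows only methoxy and pent-2-en-1-yl ethers here. A saturated pentyl ether, a butyl ether or a chain ending in an amine would separate these readings.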